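The compounds below may be only part of what the source reports. "The series", "measured", "known", "first", "only" and "open" are said of these compounds alone.

Measured compounds in hand:
compound 1, `Cc1cc(C#Cc2ccc(CCC(=O)O)cc2)nc(Cl)n1`: 2750 nM
compound 2, `O=C(O)CCc1ccc(C#Cc2cccs2)cc1`: 251 nM

Both were run in an in vitro functional assay on 1321-N1 cells for agonist activity at Free fatty acid receptor 1 (Homo sapiens), read by fluorescence, spectrophotometry and calcium flux; on this read-out higher numbers stand for an effect only at larger amounts of compound and lower numbers for an effect already at smaller amounts. Compound 2 gives 251 nM and stands at the lowest of the two numbers; its nearest neighbour, compound 1, gives 2750 nM, a gap that lies beyond the scatter. Compound 1 and compound 2 differ in more than one place, so their two values say only that much.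

Compound 3, `O=C(O)CCc1ccc(C#Cc2cncs2)cc1`, is not yet measured in this assay. It differs from compound 2 by 1,3-thiazol-5-yl in place of thiophen-2-yl on a triple-bonded carbon. For the measured compounds named here, no pair of measured compounds differing in one place is available, so the size of this step cannot be read from what has been measured. Compound 3 is expected to fall in the same region as compound 2, with a step of a 2.0-fold higher number from compound 2 to compound 3 (0.30 log units; within the scatter), which may or may not exceed the scatter. The estimate for compound 3 in this assay is 500 nM, with a range from 150 nM to 2500 nM.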

Compound 3, half-maximal effective concentration: 3890 nM
The estimate for compound 3 lay 7.8-fold (0.89 log units) below the measured number; the whole stated range lies below it.
By their numbers in this assay, from the lowest: compound 2; then compounds 1 and 3 (each within the scatter of the next).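

Working from the single-place change on the triple-bonded carbon, this assay gives a 15-fold higher number from compound 2 to compound 3 (1.19 log units; beyond the scatter) when 1,3-thiazol-5-yl replaces thiophen-2-yl. For the compounds shown here, this is the first readable step, and it shows that the measured potency is sensitive to the identity of the ring at this position, even though both groups are five-membered aromatic rings with 5 heavy atoms and differ in having 2 hetero atoms rather than 1. Nothing available explains the size of this step.

This single step cannot show whether the higher number follows from the entering ring nitrogen itself or from its particular place in the ring. On these data alone, how a furan-2-yl or a phenyl group on the same triple-bonded carbon would compare with thiophen-2-yl remains open.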